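The source may report more compounds than this note shows. Statements on the series, on what has been measured and on what is new or still open speak of the compounds shown alone.

Compound 1 `Cc1nnc(-c2ccc(N3CCC(Oc4ccccc4C(F)(F)F)CC3)nn2)s1`: 2.3 nM
Compound 2 `CC(=O)c1ccccc1OC1CCN(c2ccc(-n3ccnc3)nn2)CC1`: 34 nM
Compound 3 `CC(C)Cc1nnc(-c2ccc(N3CCC(Oc4ccccc4C(F)(F)F)CC3)nn2)o1`: 15 nM

All three were tested in an assay on microsomes from liver for inhibition of acyl-CoA desaturase 1 (Rattus norvegicus); on this read-out higher numbers stand for weaker inhibition and lower numbers for stronger inhibition. Compound 2 gives the highest number of the three, so it is the weakest inhibitor here; its nearest neighbour is compound 3, and the gap to compound 1 is the widest. For the measured compounds named here, the only step between compounds that differ in one place is a 6.5-fold higher number from compound 1 to compound 3 (0.81 log units; beyond the scatter), and it concerns the aromatic heterocycle attached to the shared core, not the six-membered aromatic ring of carbon only.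

Compound 4 `Cc1ccccc1OC1CCN(c2ccc(-n3ccnc3)nn2)CC1` has not yet been measured. It differs from compound 2 in one place: methyl in place of acetyl on an aromatic carbon. Acetyl leaves and methyl enters on an aromatic carbon of that six-membered ring. Going by the values given here, no measured step touches this ring, so the step from compound 1 to compound 3 offers no direct guide, and the data hold nothing on what exchanging acetyl for methyl does. A small weakening is expected for compound 4, a 1.8-fold higher number from compound 2 to compound 4 (0.25 log units; within the scatter). Compound 4 is therefore estimated at 60 nM, with a range from 20 nM to 200 nM.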

Compound 4, half-maximal inhibitory concentration: 39 nM
Compound 4: the middle estimate sits 1.5-fold (0.19 log units) above what was measured, within the range that was stated.
By their numbers in this assay, from the lowest: compound 1; then compound 3; then compounds 2 and 4 (each within the scatter of the next).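

On this aromatic carbon, ortho to a large group, going from 2-acetylphenyl to 2-methylphenyl gives (a 1.1-fold higher number from compound 2 to compound 4 (0.06 log units; within the scatter)) in this assay, so the two compounds cannot be told apart on this read-out. The exchange takes away two heavy atoms, a carbonyl and the only hydrogen-bond acceptor of the acetyl group, yet the number stays within the scatter, so for this pair acetyl and methyl serve equally well at this place. No measurement at hand offers an explanation for this result.

The shown compounds leave open whether this tolerance extends to quite different groups at the same place, such as methoxy, an amine or a carboxylic acid. Trifluoromethyl on this ring also remains unresolved against acetyl or methyl, since compound 1 and compound 3 differ from compound 2 and compound 4 in a second place too.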